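A few compounds are considered here, and "the series" means these few. Any claim that something is new, unique, unknown or untested is made for them only; others in the source may bear on it.

Compound 1 `O=S(=O)(Nc1ccc2oc(-c3ccccc3)nc2c1)c1ccccc1F`: in an assay on cells for inhibition of HSP60/HSP10 (Homo sapiens), with a stated time of 60 min (on this read-out lower numbers stand for stronger inhibition and higher numbers for weaker inhibition), compound 1 gives a limit, > 100000 nM.
Compound 2 `O=S(=O)(Nc1ccc2oc(-c3ccccc3)nc2c1)c1ccc(Cl)cc1`: in this assay compound 2 gives a limit, > 100000 nM.
Compound 3 `O=S(=O)(Nc1ccc2oc(-c3ccccc3)nc2c1)c1ccc(Cl)c(C(F)(F)F)c1`: in this assay compound 3 gives a limit, > 100000 nM.

Compound 2 therefore stands at the assay limit, not at a number, as do the other two measured compounds; the three together sit at the limit of > 100000 nM in this assay, at which 3 of the 3 values shown sit. Compound 4 `COc1ccc(S(=O)(=O)Nc2ccc3oc(-c4ccccc4)nc3c2)cc1` differs from compound 2 by methoxy in place of chloro on an aromatic carbon. Within the data shown here, the steps that bear on changes at the sulfonyl aryl ring are a step that the two limits leave unreadable from compound 1 to compound 2 and a step that the two limits leave unreadable from compound 2 to compound 3; both are unreadable, since each joins two limits. Among the measured compounds shown here, no measured step gives a size or a direction, so the step of a number no higher from compound 2 to compound 4 (the limit leaves the size open) is expected to be small and most likely to leave compound 4 at the limit again. The estimate for compound 4 in this assay is 100000 nM, expected between 30000 nM and 300000 nM.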

Compound 4, half-maximal inhibitory concentration: > 100000 nM
Compound 4: no number, only a limit (the forecaster's own chance of this, stated with the estimate: 75%); the middle value sits exactly at the limit.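

Compound 4 gives > 100000 nM, a limit and not a number, so the steps to it from compound 1 and compound 2 cannot be read. The compounds shown leave open whether any change on the sulfonyl aryl ring alters the read-out in this assay.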